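Sulfonyl Aryl Exchange on Compound 3: Expected Microsomal Clearance

The compounds below may be only part of what the source reports. "The series", "measured", "known", "first", "only" and "open" are said of these compounds alone.

Compound 1 (`CCn1c([C@@H](C)NS(=O)(=O)c2ccc(Cl)cc2)nc2ccccc21`) in an ADME assay (liver) for metabolic stability, with Liver microsome (Homo sapiens) as the target, read by LC-MS, using microsomes and NADPH, with a stated time of 5 min, at 37 degrees C (a higher number here means faster removal of the compound, a lower number slower removal), gives a limit of > 100 mL.min-1.g-1. Compound 2 (`CCn1c(C(C)NS(=O)(=O)c2ccc(Cl)cc2)nc2ccncc21`) in this assay gives 93 mL.min-1.g-1. Compound 3 (`CCn1c([C@@H](C)NS(=O)(=O)c2ccc(C)cc2)nc2ccc(C(F)(F)F)cc21`) in this assay gives a limit of > 100 mL.min-1.g-1.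

Compound 3 thus stands at the limit of > 100 mL.min-1.g-1 in this assay, at which 2 of the 3 values shown sit, so its clearance is only bounded from below. Compound 4 (`CCn1ncc(S(=O)(=O)N[C@H](C)c2nc3ccc(C(F)(F)F)cc3n2CC)c1C`) differs from compound 3 by 1-ethyl-5-methyl-1H-pyrazol-4-yl in place of 4-methylphenyl on a sulfonyl sulfur. Among the compounds with values here, no pair of measured compounds shows this change, and all three measured values sit high. The step of an at least 1.3-fold lower number from compound 3 to compound 4 (0.12 log units; that floor lies within the scatter) is expected to be small, not clearly beyond the usual scatter, perhaps slightly downward. Compound 4 is therefore estimated at 75 mL.min-1.g-1 in this assay, within 30 mL.min-1.g-1 to 160 mL.min-1.g-1.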

Compound 4, intrinsic clearance in microsomes: > 100 mL.min-1.g-1
Compound 4 was reported as a limit; the forecaster's own chance of this, stated with the estimate: 35%; at least 1.3-fold (0.12 log units) between middle value and limit.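

Within the data shown here, compound 3 and compound 4 both stand as limits in this assay, so no step between them can be read. The compounds shown leave open whether this sulfonyl aryl exchange changes intrinsic clearance in microsomes, with most values resting on one limit: the limit of > 100 mL.min-1.g-1 in this assay, at which 3 of the 4 values shown sit.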